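The compounds below may be only part of what the source reports. "The series", "measured", "known", "first", "only" and "open" are said of these compounds alone.

Measured so far in a functional assay on HUVEC cells (Homo sapiens) for inhibition, read by MTT assay, with a stated time of 24 h, tested at 100 uM; on this read-out higher numbers stand for more inhibition of growth at the one concentration tested and lower numbers for less inhibition of growth:

Compound 2, `COc1cc2ccc(=O)oc2cc1OCCCCBr`, gives 16.9%.
Compound 1, `COc1cc2ccc(=O)oc2cc1OCC(O)CN1CCCC1`, gives 0.3%.

Compound 2 stands highest of the two numbers in this assay. Its nearest neighbour is compound 1, whose value lies lower by a gap beyond the usual scatter, so the two compounds are genuinely told apart by this read-out.

Compound 3, `COc1cc2ccc(=O)oc2cc1OCC(O)CNC(C)C`, is the next compound to be measured. It differs from compound 2 in one place: 1-hydroxy-2-(isopropylamino)ethyl in place of 3-bromopropyl on a saturated chain carbon bound to an oxygen on an aromatic ring. The chain that enters brings a hydroxyl and an amine, a pattern compound 1 also carries on its own chain, whereas compound 2 ends in a bromine.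

Among the compounds with values here, no step between two measured compounds that differ in only one place is available, so the expectation rests on the two values alone. Since compound 1 gives 0.3%, a step downward in this assay is expected on going to the related chain of compound 3, and that step is estimated as a number 12.9 percentage points lower from compound 2 to compound 3 (beyond the scatter). For compound 3 the expected value is 4%, with a likely range from 0% to 18%.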

Compound 3, percent growth inhibition at one concentration: 6.3%
The estimate for compound 3 lay 2.3 percentage points below the measured number; low and high end bracket the measured number.
By their numbers in this assay, from the lowest: compounds 1 and 3 (each within the scatter of the next); then compound 2.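

In this assay, within the data shown here, the exchange of 3-bromopropyl for 1-hydroxy-2-(isopropylamino)ethyl on a saturated chain carbon bound to an oxygen on an aromatic ring gives a number 10.6 percentage points lower from compound 2 to compound 3 (beyond the scatter) and is the first single-place change at this position that the read-out can resolve. Within the hydroxyl-and-amine chain, isopropylamino in place of pyrrolidin-1-yl on a saturated chain carbon, two bonds along the chain from an oxygen on a saturated carbon, gives a number 6 percentage points higher from compound 1 to compound 3 (within the scatter) and so leaves these two amines unseparated in this assay. The clear gap therefore lies between the bromine-ended chain and the chain bearing a hydroxyl and an amine, while the choice between these two amines makes no clear difference, and no independent measurement offers an explanation for either result.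

The hydroxyl and the amine enter together, so the compounds shown do not assign the step to either one. A chain carrying isopropylamino without the hydroxyl, a chain ending in chlorine instead of bromine, or a longer chain ending in bromine could help to separate these contributions.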